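This account rests on a few compounds, and the source may have more. Where it says the series, first, only, none or still open, it means among the compounds named here.

Compound 1 `CS(=O)(=O)Nc1ccccc1-c1ccc(COC2CC[C@H](N3CCCCCC3)[C@H]2OC/C=C\CCC(=O)O)cc1` gives 3.98 nM in a functional assay for antagonist activity at thromboxane A2 receptor (Rattus norvegicus); a lower number here means tighter binding, a higher number weaker binding. Compound 2 `O=C(O)CC/C=C\CO[C@H]1[C@@H](OCc2ccc(-c3ccccc3)cc2)CC[C@@H]1N1CCCCCC1` gives 39.8 nM in this assay, and compound 3 `O=C(O)CC/C=C\CO[C@H]1C(OCc2ccc(-c3ccc(CO)cc3)cc2)CC[C@@H]1N1CCCCCC1` gives 20 nM. Among the measured compounds shown here, only one step between compounds differing in a single place is at hand: a 5.0-fold higher number from compound 1 to compound 3 (0.70 log units; beyond the scatter), where a 4-(hydroxymethyl)phenyl stands in place of a 2-(methanesulfonamido)phenyl on an aromatic carbon. Among the three numbers, compound 3 holds the second highest; compound 2 lies a step from it that falls within the scatter, while compound 1 lies a step away that goes beyond it.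

Compound 4 `O=C(O)CC/C=C\CO[C@H]1[C@@H](OCc2ccc(-c3ccc(CO)cc3)cc2)CC[C@@H]1N1CCCCCC1` is the next structure. Its difference from compound 3 is the two compounds have the same atoms and bonds; at least one stereo element is drawn with a configuration in one of them and without one in the other: 1 of 4 stereo elements differ; a stereocentre at a saturated ring carbon is drawn without a configuration in compound 3 and S in compound 4: the atoms and bonds are unchanged, and only the drawing of one stereocentre at a saturated ring carbon is made definite. For the measured compounds named here, no measured step bears on such a change, so no shift beyond the scatter is expected, and the expected step is a 1.3-fold lower number from compound 3 to compound 4 (0.12 log units; within the scatter). For compound 4 the estimate in this assay is 15 nM, with a range from 6 nM to 40 nM.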

Compound 4, dissociation constant: 50.1 nM
The estimate for compound 4 lay 3.3-fold (0.52 log units) below the measured number, and the stated range ends below it.
By their numbers in this assay, from the lowest: compound 1; then compounds 3, 2 and 4 (each within the scatter of the next, the first and the last beyond it).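

With no atom or bond changed, the move from an undefined stereocentre at a saturated ring carbon to the S form gives a 2.5-fold higher number from compound 3 to compound 4 (0.40 log units; beyond the scatter), the first sign in this set that stereochemistry at this carbon can matter in this assay. With that centre defined in both compounds, hydroxymethyl in place of hydrogen on an aromatic carbon gives only a 1.3-fold higher number from compound 2 to compound 4 (0.10 log units; within the scatter), so this change shows no measurable effect here. The step from compound 3 compares a defined centre with an undefined one rather than two defined configurations, and the only available explanation for it is: the fact that one of compounds 3 and 4 is drawn with a defined configuration and the other without, at the place where they differ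

The compounds shown leave open how the R configuration at this carbon compares with S. They also leave open whether an amine or a carboxylic acid in place of hydroxymethyl on that aromatic carbon would shift the number.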